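The source may hold more compounds than are shown below. What is called first, only, known or untested is meant among the compounds shown, and "the series" means these compounds.

Measured so far in an ADME assay on Huh-7 cells (Homo sapiens) for cytotoxicity; on this read-out higher numbers stand for lower toxicity in this test and lower numbers for higher toxicity in this test:
- compound 1, `N#Cc1cccc(C(=O)NC(=S)N2CCc3c(OCCCCCOc4ccc(Cl)cc4)cccc32)c1`: 9750 nM
- compound 2, `O=C(NC(=S)N1CCc2c(OCCCCCOc3ccc(Cl)cc3)cccc21)c1ccsc1`: > 50000 nM

Compound 1 gives a number in this assay. For compound 2 the value is a limit of the assay and not a number, as marked by the limit of > 50000 nM in this assay, at which 1 of the 2 values shown sits. The single measured step, an at least 5.1-fold higher number from compound 1 to compound 2 (0.70 log units; beyond the scatter), is beyond the scatter and runs toward lower toxicity in this test; on the numbers shown compound 2 therefore stands at the less toxic end of the pair, known only as a limit.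

Compound 3, `O=S(=O)(NC(=S)N1CCc2c(OCCCCCOc3ccc(Cl)cc3)cccc21)c1ccccc1`, differs from compound 2 by phenylsulfonyl in place of (thiophen-3-yl)carbonyl on an amide-type nitrogen. Going by the values given here, the change sits on the same amide-type nitrogen that the step from compound 1 to compound 2 also varied, so that step is the only one that bears on it, and it bears only indirectly: no measured pair exchanges a carbonyl for a sulfonyl. With compound 2 already sitting at the limit, any movement toward still lower toxicity could not be resolved in this assay. The expected step from compound 2 to compound 3, an at least 1.1-fold lower number from compound 2 to compound 3 (0.04 log units; that floor lies within the scatter), is none beyond the scatter. Compound 3 is estimated at 45000 nM, with a range of 15000 nM to 120000 nM.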

Compound 3, half-maximal cytotoxic concentration: > 50000 nM
Compound 3: no number, only a limit; the forecaster's own chance of this, stated with the estimate: 55%; middle value at least 1.1-fold (0.04 log units) from the limit.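

In this assay compound 3 gives > 50000 nM, which is a limit of the assay and not a number. Phenylsulfonyl in place of (3-cyanophenyl)carbonyl on the amide-type nitrogen gives an at least 5.1-fold higher number from compound 1 to compound 3 (0.70 log units; beyond the scatter), so the less toxic end of the series now holds a sulfonyl-linked group as well as a carbonyl-linked one, and among the compounds shown only the (3-cyanophenyl)carbonyl group gives a number. The step between compound 2 and compound 3 cannot be read, and no order between them can be stated, because both rest at the same ceiling: the limit of > 50000 nM in this assay, at which 2 of the 3 values shown sit.

Still open, going by these compounds, is whether the number for compound 1 goes with the nitrile or with the rest of the (3-cyanophenyl)carbonyl group; a plain benzoyl group or a (3-cyanophenyl)sulfonyl group on the same nitrogen would separate the two. Also open, on these data alone, is how far compound 2 and compound 3 actually lie from the limit, which only a read-out extending beyond it could show.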